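This account rests on a few compounds, and the source may have more. Where it says the series, first, only, none or still open, it means among the compounds named here.

Compound 1 `COc1ccc2nc(-c3c(Cl)nc(N)nc3N[C@@H]3C[C@H](CO)[C@@H](O)[C@H]3O)sc2c1` and compound 2 `CCOc1ccc2nc(-c3c(Cl)nc(N)nc3N[C@@H]3C[C@H](CO)[C@@H](O)[C@H]3O)sc2c1` share one core; compound 3 `CCNc1nc(C)c(-c2nc3ccccc3s2)c(N[C@@H]2C[C@H](CO)[C@@H](O)[C@H]2O)n1` and compound 4 `CCCNc1nc(C)c(-c2nc3ccccc3s2)c(N[C@@H]2C[C@H](CO)[C@@H](O)[C@H]2O)n1` share another, and the difference between the two cores is not broken down here. In an ADME assay on cells (Homo sapiens) for cytotoxicity, read by polymerase chain reaction, with a stated time of 3 days (a higher number here means that more compound is tolerated, a lower number that less compound is tolerated), compound 1 gives only a limit, > 25000 nM. Compound 2 likewise gives only a limit in this assay, > 25000 nM. The change between them, (methyl in place of hydrogen on a saturated chain carbon bound to an oxygen on an aromatic ring), thus made a step that the two limits leave unreadable from compound 1 to compound 2, a consequence of the limit of > 25000 nM in this assay, at which 2 of the 3 values shown sit. For the measured compounds named here, compound 3 gives 12000 nM in this assay, the only number among the three. Compound 4 carries the same kind of change, (methyl in place of hydrogen on a saturated chain carbon, two bonds along the chain from a nitrogen on an aromatic ring), set two bonds along the chain from a nitrogen on an aromatic ring rather than bound to an oxygen on an aromatic ring. Going by the values given here, the one measured example of this change is unreadable; the expectation for compound 4 rests instead on compound 3 at 12000 nM. A step of a 1.2-fold lower number from compound 3 to compound 4 (0.08 log units; within the scatter) is expected. Compound 4 is estimated at 10000 nM, between 4000 nM and 25000 nM.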

Compound 4, half-maximal cytotoxic concentration: > 25000 nM
Compound 4: only a limit was reported; the forecaster's own chance of this, stated with the estimate: 25%; middle value at least 2.5-fold (0.39 log units) from the limit.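

In this assay, the change from ethylamino to propylamino gives an at least 2.0-fold higher number from compound 3 to compound 4 (0.31 log units; beyond the scatter), so on this core the added methyl goes with more compound being tolerated. Going by these compounds, the figure for compound 4 is a limit and not a number, so the full size of this step remains unknown. The same kind of change on the other core, from compound 1 to compound 2, cannot be read, so carrying it from one core to the other is not shown, because both of those values are limits: the limit of > 25000 nM in this assay, at which 3 of the 4 values shown sit.

Open, on these data alone, is whether a longer chain, such as butylamino, on the core of compound 3 would give a readable number. Also open, as far as these compounds go, is how a carboxylic acid at the end of that chain would fare in this assay.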